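Permeability notes: ether replaces phenyl on the shared core

A few compounds are considered here, and "the series" means these few. Any claim that something is new, unique, unknown or untested is made for them only; others in the source may bear on it.

Measured compounds:
compound 1, `COc1cccc(CNCCCNc2ccnc3cc(Oc4ccccc4)ccc23)c1O`, in an ADME assay for permeability, using PAMPA, with a stated time of 30 min, at pH 7.4 (a lower number here means that the compound crosses the layer more slowly, a higher number that the compound crosses the layer faster), compound 1 gives 317 10^-6 cm/s
compound 2, `COc1cccc(Oc2ccc3c(NCCCNCc4cccc(OC)c4O)ccnc3c2)c1`, compound 2 gives 317 10^-6 cm/s
compound 3, `COc1cccc(CNCCCNc2ccnc3cc(-c4ccccc4)ccc23)c1O`, compound 3 gives 237 10^-6 cm/s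

Compound 3 holds the lowest of the three numbers, yet its separation from compound 1 (a 1.3-fold lower number from compound 1 to compound 3 (0.13 log units; within the scatter)) and from compound 2 (a 1.3-fold lower number from compound 2 to compound 3 (0.13 log units; within the scatter)) stays within the scatter, so no order among the three can be claimed. Compound 4, `COc1ccccc1Oc1ccc2c(NCCCNCc3cccc(OC)c3O)ccnc2c1`, differs from compound 3 by 2-methoxyphenoxy in place of phenyl on an aromatic carbon. Going by the values given here, the steps that bear on this are the phenoxy-for-phenyl exchange seen between compound 1 and compound 3, the related exchange between compound 2 and compound 3, and the methoxy addition no change at the digits printed from compound 1 to compound 2 (within the scatter); none moved the number beyond the scatter. In this assay the step of a 1.3-fold higher number from compound 3 to compound 4 (0.10 log units; within the scatter) is therefore expected to stay within the scatter. Compound 4 is estimated at 300 10^-6 cm/s, ranging from 190 10^-6 cm/s to 470 10^-6 cm/s.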

Compound 4, apparent permeability in the ADME assay: 317 10^-6 cm/s
The estimate for compound 4 lay 1.1-fold (0.02 log units) below the measured number; measured number inside the range.
By their numbers in the ADME assay, from the lowest: compounds 3, 1, 2 and 4 (each within the scatter of the next).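

In the ADME assay compound 4 gives 317 10^-6 cm/s: the 2-methoxyphenoxy group in place of phenyl gives a 1.3-fold higher number from compound 3 to compound 4 (0.13 log units; within the scatter), 2-methoxyphenyl in place of 3-methoxyphenyl gives no change at the digits printed from compound 2 to compound 4 (within the scatter) and methoxy in place of hydrogen gives no change at the digits printed from compound 1 to compound 4 (within the scatter), so a second methoxy placement on this group also leaves every step within the scatter. In a physicochemical assay for acid dissociation, compound 3 gives 9.47 and compound 4 gives 9.28, and the exchange of phenyl for 2-methoxyphenoxy gives a number 0.19 log units lower from compound 3 to compound 4 (within the scatter). Nothing available accounts for these results.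

Open, as far as these compounds go, is whether an amine or a carboxylic acid on the phenoxy group, in place of methoxy, would carry either number beyond the scatter.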